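Amino in place of dimethylamino on the compound 1 core

The source may report more compounds than this note shows. Statements on the series, on what has been measured and on what is new or still open speak of the compounds shown alone.

Measured so far, in an ADME assay on isolated protein for inhibition of carbonic anhydrase 4 (Homo sapiens), read by stopped-flow, with a stated time of 15 min; a higher number here means a weaker inhibitor, a lower number a stronger inhibitor:
- compound 1 `CN(C)c1cccc(S(=O)(=O)[N-][N+](=O)[O-])c1` gives 4500 nM
- compound 2 `CN(C)c1ccccc1S(=O)(=O)[N-][N+](=O)[O-]` gives 32200 nM

Compound 1 stands lowest of the two numbers in this assay; the nearest is compound 2, whose number is higher by an amount beyond the scatter. For the measured compounds named here, the two differ in more than one place, so no single step is read from them.

Compound 3 `Nc1cccc(S(=O)(=O)[N-][N+](=O)[O-])c1` is not yet measured. Relative to compound 1 the change is amino in place of dimethylamino on an aromatic carbon. Going by the values given here, no pair among the measured compounds isolates this exchange, so there is no measured step to lean on. The expectation is a step that stays within the scatter, or at most a modest move toward a lower number, with no strong direction supported by the data.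

Compound 3 is therefore estimated at 3500 nM (range 900 nM to 14000 nM), an expected step of a 1.3-fold lower number from compound 1 to compound 3 (0.11 log units; within the scatter).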

Compound 3, inhibition constant: 4300 nM
Compound 3: the middle estimate sits 1.2-fold (0.09 log units) below what was measured; measured number inside the range.
By their numbers in this assay, from the lowest: compounds 3 and 1 (each within the scatter of the next); then compound 2.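

In this assay, for the compounds shown here, the exchange of dimethylamino for amino on an aromatic carbon, meta to a group of 7 heavy atoms, gives a 1.0-fold lower number from compound 1 to compound 3 (0.02 log units; within the scatter) and is the first change that can be read in one place. At this position, the two groups cannot be told apart in this read-out, even though they differ in heavy atoms and hydrogen-bond donors. Nothing at hand accounts for this lack of separation.

Going by these compounds, whether the number stays put with other groups at this position, such as a carboxylic acid, an acetamide or a longer alkyl chain, remains open. Also open, on these data alone, is whether the same exchange on the core of compound 2 would leave its number equally unmoved.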